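The source may hold more compounds than are shown below. What is called first, only, known or untested is meant among the compounds shown, and "the series" means these compounds.

In a functional assay on HEK293 cells (Homo sapiens) for cytotoxicity (a lower number here means that less compound is tolerated, a higher number that more compound is tolerated), compound 1 `COc1ccc([C@H]2CC(=O)N(c3ccc(C#N)cc3)C2)cc1OC1CCCC1` gives > 10000 nM, which is a limit of the assay and not a number. Compound 2 `COc1ccc([C@H]2CC(=O)N(c3cccc(C)c3)C2)cc1OC1CCCC1` gives > 10000 nM, which is also a limit. Compound 2 therefore has no exact value and stands with compound 1 at the limit of > 10000 nM in this assay, at which 2 of the 2 values shown sit. Among the measured compounds shown here, the only measured step is a step that the two limits leave unreadable from compound 1 to compound 2, so it gives no size to carry forward. Compound 3 `COc1ccc([C@H]2CC(=O)N(c3ccc(C)cc3)C2)cc1OC1CCCC1` has 4-methylphenyl in place of 3-methylphenyl on an amide-type nitrogen in a ring, a change counted as 4-methylphenyl in place of 3-methylphenyl on an amide-type nitrogen in a ring. For the measured compounds named here, with the step that the two limits leave unreadable from compound 1 to compound 2 as the only guide, no change beyond the usual scatter is expected in this assay, and no direction can be predicted. The expected change is a step that the limit leaves unreadable from compound 2 to compound 3. The assay may well report only a limit again. For compound 3 the estimated half-maximal cytotoxic concentration is 12000 nM, with an expected range of 7000 nM to 30000 nM.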

Compound 3, half-maximal cytotoxic concentration: > 10000 nM
Compound 3: only a limit was reported (the forecaster's own chance of this, stated with the estimate: 90%); the middle value lies beyond the limit too.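

In this assay, among the compounds shown here, compound 1, compound 2 and compound 3 all sit at the same limit, so no step among them can be read: the limit of > 10000 nM in this assay, at which 3 of the 3 values shown sit. As far as these compounds go, how far each compound lies beyond that limit, and whether the three aromatic groups differ at all in this read-out, stays open.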